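A few compounds are considered here, and "the series" means these few. Any claim that something is new, unique, unknown or untested is made for them only; others in the source may bear on it.

Compound 1 `Cn1cnnc1SCC(=O)Nc1ccc(-c2nc(-c3ccccc3)c(-c3ccccc3)n2C)cc1` — 40.8%
Compound 2 `Cc1nnc(SCC(=O)Nc2ccc(-c3nc(-c4ccccc4)c(-c4ccccc4)n3C)cc2)s1` — 39.9%
Compound 3 `CCN1CCN(CC(=O)Nc2ccc(-c3nc(-c4ccccc4)c(-c4ccccc4)n3C)cc2)CC1` — 13.9%

In a functional assay on HT-29 cells (Homo sapiens) for cytotoxicity, read by MTT assay, with a stated time of 24 h, tested at 1.6 ug/mL (a lower number here means a weaker effect, a higher number a stronger effect of the compound at the concentration tested), compound 3 stands lowest of the three numbers, beyond the scatter below both compound 1 and compound 2. The two steps that reach it, a number 26.9 percentage points lower from compound 1 to compound 3 (beyond the scatter) and a number 26 percentage points lower from compound 2 to compound 3 (beyond the scatter), both replace a sulfur-linked heterocycle with the ethylpiperazine and lower the read-out modestly. Compound 4 `Cn1c(-c2ccc(NC(=O)CN3CCN(Cc4ccccc4)CC3)cc2)nc(-c2ccccc2)c1-c1ccccc1` is compound 3 with phenyl in place of methyl on a saturated chain carbon bound to an amine nitrogen in a ring. Going by the values given here, none of the measured steps touches this chain on the piperazine; they all alter the group on the carbon bound to the carbonyl carbon, so they offer no direct guide. With nothing to suggest a gain, the step of a number 2.1 percentage points higher from compound 3 to compound 4 (within the scatter) is expected to stay within the scatter. Compound 4 is therefore estimated at 16%, in the range 5% to 32%.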

Compound 4, a percentage reported as activity, at one concentration (the size of the read-out at that concentration, not a potency): 26%
Estimate against measurement, compound 4: 10 percentage points below, and the stated range covers the measured number.
By their numbers in this assay, from the lowest: compound 3; then compound 4; then compounds 2 and 1 (each within the scatter of the next).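

In this assay, the change from ethyl to benzyl gives a number 12.1 percentage points higher from compound 3 to compound 4 (beyond the scatter), the first step shown on the chain on the piperazine; the earlier steps altered only the group on the saturated chain carbon bound to a carbonyl carbon. It shows that phenyl in place of methyl at this place moves the read-out modestly upward. Nothing measured here accounts for this gain. Open, going by these compounds, is whether a longer chain, such as 2-phenylethyl, or a pyridine ring in place of the phenyl would raise the number further.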